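Chain extension by one carbon from compound 2 to compound 3

The source may hold more compounds than are shown below. What is called first, only, known or untested is meant among the compounds shown, and "the series" means these compounds.

Two compounds have numbers in an assay on isolated protein for inhibition of Aromatase (Homo sapiens), read by fluorescence and colorimetric assay, with a stated time of 30 min; on this read-out higher numbers stand for weaker inhibition and lower numbers for stronger inhibition. Compound 1 `CCCCCCCc1cn(C(c2ccccc2)c2ccccc2)nn1` gives 19400 nM in this assay. Compound 2 `CCCCCCc1cn(Cc2ccccc2)nn1` gives 7470 nM in this assay, the lower of the two numbers, and the gap between compound 2 and compound 1 lies beyond the scatter; these two differ in more than one place, so only the two values themselves are taken from the pair. Compound 3 `CCCCCCCc1cn(Cc2ccccc2)nn1` is not yet measured in this assay. It differs from compound 2 by methyl in place of hydrogen on a saturated chain carbon, six bonds along the chain from an aromatic carbon. Within the data shown here, no measured pair shows what one more chain carbon does here, so no direction is assumed, and the step of a 1.0-fold higher number from compound 2 to compound 3 (0.00 log units; within the scatter) is expected to stay within the scatter. Compound 3 is expected to give 7500 nM in this assay, with a range from 3000 nM to 19000 nM.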

Compound 3, half-maximal inhibitory concentration: 9530 nM
Compound 3: the middle estimate sits 1.3-fold (0.10 log units) below what was measured; low and high end bracket the measured number.
By their numbers in this assay, from the lowest: compounds 2 and 3 (each within the scatter of the next); then compound 1.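

In this assay, methyl in place of hydrogen on a saturated chain carbon, six bonds along the chain from an aromatic carbon, gives a 1.3-fold higher number from compound 2 to compound 3 (0.11 log units; within the scatter) and so offers no sign that this extra chain carbon matters in this series. Among these compounds, compound 3 also provides the first comparison in one place at the other substituent: hydrogen in place of phenyl on a saturated chain carbon bound to an aromatic carbon and an aromatic nitrogen gives a 2.0-fold lower number from compound 1 to compound 3 (0.31 log units; beyond the scatter) and counts as a modest step. No supporting evidence bears on either step.

From the compounds shown here alone, whether a longer chain, or a chain carrying an amine or a carboxylic acid, would move the number beyond the scatter remains open. Also open, going by these compounds, is whether the phenyl step holds with other chain lengths.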